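Compound 3: exchanging one group on the shared core

The source may hold more compounds than are shown below. What is called first, only, known or untested is meant among the compounds shown, and "the series" means these compounds.

Among the measured compounds shown here, in a physicochemical assay for solubility, in simulated intestinal fluid, measured as thermodynamic solubility, at pH 6.8 (on this read-out higher numbers stand for higher solubility and lower numbers for lower solubility), compound 2 `CCC(CC)N1CCN(c2nc3c(c(Nc4ccc(C(F)(F)F)cc4)n2)CCN(c2ncccc2C(F)(F)F)CC3)CC1` gives 109 ug/mL, the only true number so far. Compound 1 `NC1CCN(c2nc3c(c(Nc4ccc(C(F)(F)F)cc4)n2)CCN(c2ncccc2C(F)(F)F)CC3)C1` gives > 215 ug/mL, which is a limit of the assay and not a number.

Compound 3 `CNC1CCN(c2nc3c(c(Nc4ccc(C(F)(F)F)cc4)n2)CCN(c2ncccc2C(F)(F)F)CC3)C1` keeps the core of compound 2, but 3-(methylamino)pyrrolidin-1-yl takes the place of 4-(pentan-3-yl)piperazin-1-yl on an aromatic carbon (3-(methylamino)pyrrolidin-1-yl in place of 4-(pentan-3-yl)piperazin-1-yl on an aromatic carbon). For the measured compounds named here, one measured step bears on this: an at least 1.9-fold lower number from compound 1 to compound 2 (0.29 log units; that floor lies within the scatter), with 4-(pentan-3-yl)piperazin-1-yl entering in place of 3-aminopyrrolidin-1-yl. Its size is only a floor, and that floor lies within the scatter.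

The exchange in compound 3 resembles that step run backwards, starting from compound 2 at 109 ug/mL, so a move of similar size towards a higher number in this assay is expected, though it may barely clear the scatter. The estimated change is a 2.0-fold higher number from compound 2 to compound 3 (0.30 log units; within the scatter). The estimate for compound 3 is 220 ug/mL, with an expected range of 120 ug/mL to 420 ug/mL. The assay may also report only a limit for this compound.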

Compound 3, solubility: 233 ug/mL
Beside the measured number, compound 3's estimate is 1.1-fold (0.02 log units) below it; measured number inside the range.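

In this assay, this exchange on the aromatic carbon between two ring nitrogen atoms now has a readable size: a 2.1-fold higher number from compound 2 to compound 3 (0.33 log units; beyond the scatter). The earlier step from compound 1 to compound 2 offered only a floor that lay within the scatter, whereas this one runs between two true numbers and lies beyond the scatter, though only modestly, so the group at this position can move the read-out by a measurable amount. The step that places methyl on the amine nitrogen cannot be read because compound 1 carries a limit and not a number: the limit of > 215 ug/mL in this assay, at which 1 of the 3 values shown sits.

Ring size, the pentan-3-yl chain and the count of hydrogen-bond donors all change together in the exchange, and the compounds shown do not separate their shares of the step. Also open, as far as these compounds go, is how the read-out would respond at this position to a 4-methylpiperazin-1-yl group, which would keep the six-membered ring and lose only the longer chain, or to a 3-(dimethylamino)pyrrolidin-1-yl group, which would keep the five-membered ring with no amine hydrogen.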